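Notes on the step from compound 2 to compound 4

The compounds below may be only part of what the source reports. "The series", "measured", "known", "first", "only" and "open" are said of these compounds alone.

Compound 1 `CCCCCCCCCCCCCC(=O)O[C@H]1CCC(NC(=O)[C@H](OC)[C@H](O)[C@@H](O)[C@H](O)/C=C/C(C)(C)C)C(=O)N(C)C1`: 10 nM
Compound 2 `CO[C@@H](C(=O)NC1CC[C@@H](OC(=O)C2CCCCC2)CNC1=O)[C@H](O)[C@@H](O)[C@H](O)/C=C/C(C)(C)C`: 4 nM
Compound 3 `CCCCCCCCCCOc1ccc(C(=O)O[C@@H]2CCC(NC(=O)[C@H](OC)[C@H](O)[C@@H](O)[C@H](O)/C=C/C(C)(C)C)C(=O)NC2)cc1`: 10 nM

In an in vivo functional assay on the whole organism (MDA-MB-435 cells, Homo sapiens) for antiproliferative activity (on this read-out lower numbers stand for stronger inhibition and higher numbers for weaker inhibition), compound 2 holds the lowest number of the three, at 4 nM, and the other two lie beyond the scatter above it. Compound 4 `CO[C@@H](C(=O)NC1CC[C@@H](OC(=O)CCc2cccnc2)CNC1=O)[C@H](O)[C@@H](O)[C@H](O)/C=C/C(C)(C)C` is not yet measured. Its change from compound 2 is 2-(pyridin-3-yl)ethyl in place of cyclohexyl on a carbonyl carbon. Going by the values given here, no measured pair isolates a single change. Compound 3, which also carries an aromatic ring on that carbonyl, gives 10 nM, so a modest rise is the working expectation, possibly not beyond the scatter. The expected move is a 2.5-fold higher number from compound 2 to compound 4 (0.40 log units; beyond the scatter). For compound 4 the estimate is 10 nM, within 3 nM to 35 nM.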

Compound 4, half-maximal inhibitory concentration: 460 nM
For compound 4 the middle estimate is 46-fold (1.66 log units) below the measured one, outside the stated range (above it).
By their numbers in this assay, from the lowest: compound 2; then compounds 1 and 3 (each within the scatter of the next); then compound 4.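

In this assay, going by these compounds alone, this position proves highly sensitive to what sits on the carbonyl carbon: 2-(pyridin-3-yl)ethyl in place of cyclohexyl gives a 120-fold higher number from compound 2 to compound 4 (2.06 log units; beyond the scatter), a loss that the earlier compounds could not reveal. Within the data shown here, this is the first step that isolates a single change. Nothing shown accounts for its size.

Open, from the compounds shown here alone, is whether the loss goes with the ring nitrogen or with the ethyl link. A 2-phenylethyl group, or pyridin-3-yl directly on that carbonyl carbon, would separate the two.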